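Methyl for fluoro on the aryl amide of compound 1

A few compounds are considered here, and "the series" means these few. Any claim that something is new, unique, unknown or untested is made for them only; others in the source may bear on it.

Measured so far:
compound 1 `COc1cc2ncnc(NNC(=S)NC(=O)c3ccc(F)cc3)c2cc1OC`: 25800 nM
compound 2 `Cc1ccc(C(=O)NC(=S)NNc2ncnc3ccccc23)cc1`: 7820 nM
compound 3 `COc1ccccc1C(=O)NC(=S)NNc1ncnc2ccccc12`: 8700 nM

In a functional assay on MCF7 cells (Homo sapiens) for cytotoxicity, read by MTT assay, with a stated time of 72 h (a lower number here means a stronger inhibitor, a higher number a weaker inhibitor), compound 1 gives the highest of the three numbers, and both compound 3 and compound 2 give lower numbers by more than the usual scatter. Compound 4 `COc1cc2ncnc(NNC(=S)NC(=O)c3ccc(C)cc3)c2cc1OC` is compound 1 with one change: methyl in place of fluoro on an aromatic carbon. Among the compounds with values here, no measured pair shows a fluoro replaced by a methyl, so the only step that bears on it is the one on the same aryl amide, a 1.1-fold higher number from compound 2 to compound 3 (0.05 log units; within the scatter), where a different change of substituent on that ring left the number within the scatter. On that basis compound 4 is expected to stay close to compound 1, with a step of a 1.1-fold lower number from compound 1 to compound 4 (0.03 log units; within the scatter) that is not expected to go beyond the scatter in either direction. The estimate for compound 4 in this assay is therefore 24000 nM, with a range from 9000 nM to 60000 nM.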

Compound 4, half-maximal inhibitory concentration: 22300 nM
For compound 4 the middle estimate is 1.1-fold (0.03 log units) above the measured one, within the range that was stated.
By their numbers in this assay, from the lowest: compounds 2 and 3 (each within the scatter of the next); then compounds 4 and 1 (each within the scatter of the next).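

Within the data shown here, the step of a 1.2-fold lower number from compound 1 to compound 4 (0.06 log units; within the scatter) in this assay is the first direct reading of this change at this place, on an aromatic carbon para to a large group. The earlier compounds shown here offered only a different substituent change on a different core, whereas this pair tests methyl against fluoro on the core of compound 1, and at this scatter the 4-methylphenyl and 4-fluorophenyl amides cannot be told apart. No supporting data are available to explain this outcome.

From the compounds shown here alone, whether an amine, a carboxylic acid or a longer chain such as butyl at the same place would move the number beyond the scatter stays open. Also open, going by these compounds, is whether methyl and fluoro would read alike on the core of compound 2.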